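A few compounds are considered here, and "the series" means these few. Any claim that something is new, unique, unknown or untested is made for them only; others in the source may bear on it.

Compound 1, `O=C1C=COC(/C=C/c2ccccc2)C1`, opens the set. In a functional assay on NCI-H460 cells (Homo sapiens) for inhibition, read by sulforhodamine B assay, with a stated time of 48 h (on this read-out higher numbers stand for weaker inhibition of growth and lower numbers for stronger inhibition of growth), compound 1 gives 82.4 uM. Compound 2, `COc1ccc(/C=C/C2CC(=O)C=CO2)cc1`, differs from it by methoxy in place of hydrogen on an aromatic carbon, a change that made a 1.8-fold higher number from compound 1 to compound 2 (0.26 log units; within the scatter); in this assay compound 2 gives 149 uM. Compound 3, `COc1ccc(/C=C/C2CC=CC(=O)O2)cc1OC`, rests on another core, and the difference between the two cores is not broken down here. In this assay compound 3 gives 14.6 uM. Compound 4, `COc1cc(OC)c(OC)cc1/C=C/C1CC=CC(=O)O1`, is not yet measured. From compound 3 it differs by methoxy in place of hydrogen on an aromatic carbon, the same kind of change as that from compound 1 to compound 2, but here the new group sits ortho to a group of 9 heavy atoms, meta to a methoxy group and para to a methoxy group, whereas in compound 2 it sits para to a group of 9 heavy atoms. A step of a 1.4-fold higher number from compound 3 to compound 4 (0.14 log units; within the scatter) is expected because a 1.8-fold higher number from compound 1 to compound 2 (0.26 log units; within the scatter) gave no clear move. The estimate for compound 4 in this assay is 20 uM, expected to lie between 7 uM and 60 uM.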

Compound 4, concentration for growth inhibition (reported as GI): 9.8 uM
Compound 4: middle estimate off by 2.0-fold (0.31 log units), on the high side; the range from low to high includes it.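

In this assay, methoxy in place of hydrogen on an aromatic carbon gives a 1.5-fold lower number from compound 3 to compound 4 (0.17 log units; within the scatter), which on its own is no clear move. Neither step alone is a clear move, yet the gap between them shows that this change does not carry from one core to the other as a step of fixed size: the same change on two cores in this assay, a 1.8-fold higher number (0.26 log units; within the scatter) from compound 1 to compound 2 and a 1.5-fold lower number (0.17 log units; within the scatter) from compound 3 to compound 4, 2.7-fold (0.43 log units) apart, beyond the scatter of two such steps. This does not show whether the core or the place of the new group on the aromatic ring lies behind the gap, as the two pairs differ in both.

Still open, from the compounds shown here alone, is how methoxy behaves at one and the same place on both cores. Also open, going by these compounds, is whether an amine, a carboxylic acid or a longer chain such as ethoxy would follow either step.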